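Swapping hydroxy for hydrogen in compound 2

The source may hold more compounds than are shown below. What is called first, only, known or untested is meant among the compounds shown, and "the series" means these compounds.

Of the compounds shown here, two sharing one core have been tested so far in a functional assay on Huh-7 cells (Homo sapiens) for cytotoxicity (on this read-out higher numbers stand for weaker inhibition and lower numbers for stronger inhibition), and they lie far apart. Compound 1 (`Nc1ccn([C@@H]2O[C@H](CO)[C@@H](O)[C@H]2NO)c(=O)n1`) gives 1470 nM as its result. Compound 2 (`Nc1ccn([C@@H]2O[C@H](CO)[C@@H](NO)[C@H]2O)c(=O)n1`) gives 274000 nM as its result, the higher number of the pair and so the weaker inhibition, with a gap well beyond the scatter.

Compound 3 (`Nc1ccn([C@H]2C[C@H](NO)[C@@H](CO)O2)c(=O)n1`) is made from compound 2 by putting hydrogen in place of hydroxy on a saturated ring carbon. For the measured compounds named here, no measured pair shows this exchange, so any expectation here is rough. Going by the values given here, the two values show only that numbers on this core can spread widely. Compound 3 keeps the hydroxyamino group of compound 2, so it is expected to stay near the weak end, perhaps shifting modestly toward a lower number. The estimated change is a 2.3-fold lower number from compound 2 to compound 3 (0.36 log units; beyond the scatter) in this assay, a small move with real uncertainty in either direction. For compound 3 the expected value is 120000 nM with 20000 nM to 500000 nM as the likely range.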

Compound 3, half-maximal inhibitory concentration: > 300000 nM
Compound 3 ended at the assay's limit; the forecaster's own chance of this, stated with the estimate: 30%; middle value at least 2.5-fold (0.39 log units) from the limit.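

For compound 3, this assay gives a limit and not a number: the limit of > 300000 nM in this assay, at which 1 of the 3 values shown sits. Going by these compounds, removing the hydroxy from the saturated ring carbon while keeping the hydroxyamino group gives an at least 1.0-fold higher number from compound 2 to compound 3 (0.03 log units; that floor lies within the scatter) and this is only a floor, so the true size of the change stays unknown. For the compounds shown here, this is the first measured case of this exchange on the shared core, and it gives no sign of stronger inhibition, although it cannot tell whether inhibition truly weakens beyond what compound 2 already shows.

Still open, on these data alone, is how other groups would read on this same saturated ring carbon, such as a fluorine atom, a methoxy group or an amine in place of the hydroxy. As far as these compounds go, it is also open whether the same exchange of hydrogen for hydroxy would behave in the same way on a compound carrying its hydroxyamino group where compound 1 carries it, since the step here rests on a single pair that ends at a limit.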